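A few compounds are considered here, and "the series" means these few. Any claim that something is new, unique, unknown or untested is made for them only; others in the source may bear on it.

Of the compounds shown here, two with a shared core have been measured in a functional assay on the whole organism (blood) with Rattus norvegicus as the target, at a dose of 100 mg/kg by the oral route; on this read-out lower numbers stand for less inhibition and higher numbers for more inhibition at the one dose given (going by the name of the read-out). Compound 1, `Cc1ccc(N2CCN(CC(O)COc3ccc(C#N)cc3)CC2C)cc1`, gives 40.3% in this assay. Compound 2, `N#Cc1ccc(OCC(O)CN2CCN(c3ccc(F)cc3)CC2)cc1`, gives 38.6% in this assay. Compound 2 has the lower of the two figures, but its gap to compound 1 is within the usual scatter of repeated measurements, so the two readings cannot be told apart.

Compound 3, `COc1ccccc1N1CCN(CC(O)COc2ccc(C#N)cc2)CC1`, has not yet been measured. It differs from compound 2 in one place: 2-methoxyphenyl in place of 4-fluorophenyl on an amine nitrogen in a ring. The aryl group on the amine nitrogen in the ring is swapped, and one hydrogen-bond acceptor is gained.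

Among the compounds with values here, no measured pair shows what exchanging the aryl group on that nitrogen does in this assay, so there is no step to lean on. Within the data shown here, the only comparison available, compound 1 against compound 2, shows that changing the substituents on that aryl group left the reading within the scatter. On that basis the step is expected to be small, with no direction favoured: for compound 3 the expected step is a number 1.4 percentage points higher from compound 2 to compound 3 (within the scatter), with inhibition of 40% and a range from 20% to 60%.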

Compound 3, a percentage reported as inhibition, in the whole organism at one dose (the size of the read-out at that dose, not a potency): 33.5%
The estimate for compound 3 lay 6.5 percentage points above the measured number, and the stated range covers the measured number.
By their numbers in this assay, from the lowest: compounds 3, 2 and 1 (each within the scatter of the next).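

Within the data shown here, this is the first step in this assay in which one aryl group is exchanged for another on the amine nitrogen in the ring, while the rest of compound 2 stays the same. Replacing 4-fluorophenyl with 2-methoxyphenyl adds a hydrogen-bond acceptor and gives a step (a number 5.1 percentage points lower from compound 2 to compound 3 (within the scatter)) that leaves compound 2 and compound 3 indistinguishable in this whole-animal test at the one dose given. This single pair therefore shows that these two aryl groups cannot be separated by this read-out, although it does not show how other groups at this position would behave. No measurement is available that could explain this result.

The compounds shown leave open whether a non-aromatic group on that nitrogen, such as cyclohexyl or a simple methyl, would produce a step beyond the usual scatter. They also leave open what a carboxylic acid in place of the nitrile, or a longer chain between the nitrogen-containing ring and the oxygen-bearing aromatic ring, would do to the reading.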